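A few compounds are considered here, and "the series" means these few. Any claim that something is new, unique, unknown or untested is made for them only; others in the source may bear on it.

In an ADME assay on the whole organism (Rattus norvegicus, strain Wistar Han) for pharmacokinetics, read by LC-MS, with a stated time of 7 h (a higher number here means faster removal of the compound, a lower number slower removal), compound 1 `CNC(=O)c1cc(C(=O)N[C@H]2CC[C@H](O)CC2)c([C@@H](C)c2cccc(Cl)c2)o1` gives 55 mL/min/kg and compound 2 `CNC(=O)c1cc(C(=O)N[C@H]2[C@@H]3C[C@@H](O)C[C@@H]32)c([C@@H](C)c2ccccc2)o1` gives 41 mL/min/kg. These two numbers lie within the usual scatter of each other, so compound 2 cannot be told apart from compound 1 on this measure. Compound 3 `CNC(=O)c1cc(C(=O)N[C@H]2CC[C@H](O)CC2)c([C@@H](C)c2ccccc2)o1` has not yet been measured. It comes from compound 2 through a single change on an amide-type nitrogen, where a 4-hydroxycyclohexyl group takes the place of the two-ring group: a group of 7 heavy atoms (6 carbon, 1 oxygen; one six-membered non-aromatic ring of carbon only) in place of a group of 7 heavy atoms (6 carbon, 1 oxygen; one three-membered non-aromatic ring of carbon only, one five-membered non-aromatic ring of carbon only), on an amide-type nitrogen. For the measured compounds named here, the two measured compounds differ in more than one place, so no measured step shows what this change does on its own. With so little to go on, no step beyond the scatter is expected in this assay. The estimated 1.1-fold higher number from compound 2 to compound 3 (0.06 log units; within the scatter) is therefore small. For compound 3 the expected clearance is 47 mL/min/kg, with an estimated range of 27 mL/min/kg to 75 mL/min/kg.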

Compound 3, clearance in the Rattus norvegicus assay: 30 mL/min/kg
Beside the measured number, compound 3's estimate is 1.6-fold (0.19 log units) above it; measured number inside the range.
By their numbers in the Rattus norvegicus assay, from the lowest: compounds 3, 2 and 1 (each within the scatter of the next).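

For the compounds shown here, in the Rattus norvegicus assay compound 3 gives 30 mL/min/kg and supplies the first steps that change only one place: putting 4-hydroxycyclohexyl on the amide-type nitrogen in place of the two-ring group gives a 1.4-fold lower number from compound 2 to compound 3 (0.14 log units; within the scatter) and putting hydrogen in place of chloro on an aromatic carbon gives a 1.8-fold lower number from compound 1 to compound 3 (0.26 log units; within the scatter). Neither change can therefore be told apart from repeat-measurement noise in clearance, so in these compounds both the two-ring group and the chloro can be exchanged without a clear effect on this measure. In a physicochemical assay for lipophilicity (a lower number here means a more polar compound, a higher number a more lipophilic compound), compound 2 gives 2.8 and compound 3 gives 2.8, the exchange on the nitrogen gives no change at the digits printed from compound 2 to compound 3 (within the scatter), and nothing measured here offers a reason for any of these results.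

Still open, on these data alone, is whether a clearly different group on that nitrogen, such as 4-aminocyclohexyl or a longer chain ending in a carboxylic acid, would move clearance beyond the scatter. Also open, as far as these compounds go, is whether fluoro or methoxy on the aromatic ring would do so.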